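Methoxy Added to the Benzoyl Arm of Compound 3

This account rests on a few compounds, and the source may have more. Where it says the series, first, only, none or still open, it means among the compounds named here.

The series starts from compound 1 `CC1(C)C=C(n2ccccc2=O)c2ccccc2O1`, which in a functional assay (aorta) with Rattus norvegicus as the target (on this read-out higher numbers stand for higher potency (the scale is a negative logarithm) and lower numbers for lower potency), gives 5.43. Two substituted analogues stand beside it. Compound 2 `COc1ccc2c(c1)C(n1ccccc1=O)=CC(C)(C)O2` gives 6.55 in this assay, and compound 3 `CC1(C)C=C(n2ccccc2=O)c2cc(C(=O)c3ccccc3)ccc2O1` gives 6.61. The step of a number 1.12 log units higher from compound 1 to compound 2 (beyond the scatter) comes from methoxy in place of hydrogen on an aromatic carbon, and the step of a number 1.18 log units higher from compound 1 to compound 3 (beyond the scatter) comes from benzoyl in place of hydrogen on an aromatic carbon, which is also how the core of compound 3 differs from the core of compound 1. Between compound 2 and compound 3 the step is a number 0.06 log units higher from compound 2 to compound 3 (within the scatter), so these two cannot be ordered against each other.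

Compound 4 `COc1ccc(C(=O)c2ccc3c(c2)C(n2ccccc2=O)=CC(C)(C)O3)cc1` is not yet measured. It differs from compound 3 by methoxy in place of hydrogen on an aromatic carbon. Among the compounds with values here, this is the same kind of change as the one from compound 1 to compound 2, but not the same: there the place was on a six-membered aromatic ring of carbon only, part of a fused or bridged system of two rings, meta to a fused ring and para to a fused ring, whereas here the place is para to a large group on a ring that is not fused. The earlier step was large; for compound 4 a smaller step, a number 0.19 log units higher from compound 3 to compound 4 (within the scatter), is expected, resting on the observation that compound 3 already gives 6.61 and on the different surroundings of the new methoxy. The value of compound 4 in this assay is estimated at 6.8, with a range from 6.2 to 7.4.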

Compound 4, logarithm of the reciprocal of the active concentration, log(1/C): 6.15
For compound 4 the middle estimate is 0.65 log units above the measured one; the measured number lies below the stated range.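

In this assay, methoxy in place of hydrogen on the benzoyl arm, the change that reads phenyl to 4-methoxyphenyl, gives a step of a number 0.46 log units lower from compound 3 to compound 4 (beyond the scatter), so the gain seen when methoxy entered the core of compound 1 does not recur here. The same change therefore cannot be carried from one place in this series to another with its size or its direction kept: the same change on two cores in this assay, a number 1.12 log units higher (beyond the scatter) from compound 1 to compound 2 and a number 0.46 log units lower (beyond the scatter) from compound 3 to compound 4, 1.58 log units apart, beyond the scatter of two such steps. The comparison rests on a single pair on each side, and the two pairs differ both in the core that receives the methoxy and in the surroundings of the place, so it does not show which of these sets the direction of the step, nor does it give any reason for the reversal.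

The compounds shown leave open whether a hydroxy, an amine or a carboxylic acid in the place of the new methoxy would also lie under compound 3, or whether the drop belongs to methoxy alone. They also leave open what methoxy on the benzoyl arm would do on a core that already carries a methoxy of its own, as compound 2 does.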